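Notes on thiophen-2-yl in place of 3,5-dimethylphenyl

The source may report more compounds than this note shows. Statements on the series, on what has been measured and on what is new or still open speak of the compounds shown alone.

Of the compounds shown here, three on the shared core have numbers so far in a functional assay on KB cells (Homo sapiens) for cytotoxicity; a lower number here means that less compound is needed, a higher number that more compound is needed for the effect. Compound 1 `COC1=C(C)C(=O)/C(=C(O)/C=C/c2ccc(OC)cc2)C(=O)C1(C)C` gives 2.9 ug/mL, compound 2 `COC1=C(C)C(=O)/C(=C(O)/C=C/c2ccccc2C)C(=O)C1(C)C` gives 1.6 ug/mL, and compound 3 `COC1=C(C)C(=O)/C(=C(O)/C=C/c2cc(C)cc(C)c2)C(=O)C1(C)C` gives 1.6 ug/mL. Compound 3 stands level with compound 2, and all three values lie within the scatter of one another.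

The next structure is compound 4 `COC1=C(C)C(=O)/C(=C(O)/C=C/c2cccs2)C(=O)C1(C)C`, not yet measured. The change is thiophen-2-yl in place of 3,5-dimethylphenyl on a double-bonded chain carbon bound to a double-bonded chain carbon.

For the measured compounds named here, three measured steps bear on it, all at this same place: a 1.8-fold lower number from compound 1 to compound 2 (0.26 log units; within the scatter), a 1.8-fold lower number from compound 1 to compound 3 (0.26 log units; within the scatter) and no change at the digits printed from compound 2 to compound 3 (within the scatter). Each lies within the scatter, so this assay has so far shown little response to changes at this place. All of those steps exchange one six-membered aromatic ring of carbon only for another, however. Going by the values given here, no measured compound carries a five-membered aromatic ring with 1 hetero atom, so the new group is untested and the range has to stay wide.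

No step beyond the scatter is expected, and no firm direction. The expected step is a 1.3-fold higher number from compound 3 to compound 4 (0.10 log units; within the scatter). For compound 4 the estimated value is 2 ug/mL, with an expected range from 1 ug/mL to 4 ug/mL.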

Compound 4, concentration for half-maximal effect: 3.4 ug/mL
Compound 4: the middle estimate sits 1.7-fold (0.23 log units) below what was measured; the range from low to high includes it.
By their numbers in this assay, from the lowest: compounds 2, 3, 1 and 4 (each within the scatter of the next, the first and the last beyond it).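

In this assay this place now gives its first steps beyond the scatter, both modest: a 2.1-fold higher number from compound 3 to compound 4 (0.33 log units; beyond the scatter) and a 2.1-fold higher number from compound 2 to compound 4 (0.33 log units; beyond the scatter) for thiophen-2-yl in place of 3,5-dimethylphenyl and of 2-methylphenyl. The five-membered aromatic ring with 1 hetero atom does not stand apart from all the six-membered rings, however: a 1.2-fold higher number from compound 1 to compound 4 (0.07 log units; within the scatter) leaves compound 4 within the scatter of the 4-methoxyphenyl compound, so these four compounds show no separation by ring type alone. Nothing measured here accounts for the difference between these steps.

From the compounds shown here alone, all four compounds carry a single aromatic ring at this place on an unchanged core, so it remains open how this assay would respond to furan-2-yl, a pyridine ring, unsubstituted phenyl, or a non-aromatic group such as cyclohexyl, an amine or a carboxylic acid. Going by these compounds, it also remains open whether the modest steps seen with thiophen-2-yl would recur with the sulfur-bearing ring carrying a methyl group, or on a core altered elsewhere.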